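Imidazolyl for acetamido on a weakly binding hydrazone

The source may report more compounds than this note shows. Statements on the series, on what has been measured and on what is new or still open speak of the compounds shown alone.

Compound 1, `CC(=O)Nc1ccc(/C=N/Nc2nc(N)c3ncn([C@@H]4O[C@H](CO)[C@@H](O)[C@H]4O)c3n2)cc1`, marks the point of departure. In an assay on CHO-K1 cells for displacement of a labelled ligand from adenosine receptor A1 (Homo sapiens), read by scintillation counting, with a stated time of 60 min (on this read-out lower numbers stand for stronger inhibition and higher numbers for weaker inhibition), compound 1 gives > 10000 nM, which is a limit of the assay rather than a number; it sits at the limit of > 10000 nM in this assay, at which 2 of the 3 values shown sit. Compound 2, `CCOc1cc(/C=N/Nc2nc(N)c3ncn([C@@H]4O[C@H](CO)[C@@H](O)[C@H]4O)c3n2)ccc1O`, gives 6940 nM in this assay. Compound 3, `CCCOc1ccc(/C=N/Nc2nc(N)c3ncn([C@@H]4O[C@H](CO)[C@@H](O)[C@H]4O)c3n2)cc1`, gives > 10000 nM in this assay, again a limit. The steps from compound 1 are an at least 1.4-fold lower number from compound 1 to compound 2 (0.15 log units; that floor lies within the scatter) and a step that the two limits leave unreadable from compound 1 to compound 3. Compound 4, `Nc1nc(N/N=C/c2ccc(-n3ccnc3)cc2)nc2c1ncn2[C@@H]1O[C@H](CO)[C@@H](O)[C@H]1O`, carries the change (1H-imidazol-1-yl in place of acetamido on an aromatic carbon). Both measured steps from compound 1 stay at or within the scatter, so no step beyond the scatter is expected in this assay, and a limit again is likely. Compound 4 is expected to give 12000 nM, in the range 4000 nM to 40000 nM. The expected step is a step that the limit leaves unreadable from compound 1 to compound 4.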

Compound 4, inhibition constant: > 10000 nM
Compound 4 gave a limit, no number; the forecaster's own chance of this, stated with the estimate: 65%; the middle value does not contradict the limit.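

Going by these compounds alone, compound 4 also stops at a limit of this assay, the one it shares with compound 1 and compound 3: the limit of > 10000 nM in this assay, at which 3 of the 4 values shown sit. A five-membered aromatic ring on this aromatic carbon thus gives no number in this assay, just as acetamido and propoxy do not. Within the data shown here, the steps to compound 4 from compound 1 and compound 3 cannot be read, and the only readable step is an at least 1.4-fold higher number from compound 2 to compound 4 (0.15 log units; that floor lies within the scatter).

On these data alone, how far compound 1, compound 3 and compound 4 lie beyond that limit stays open. So does whether an amine, a carboxylic acid or a longer alkoxy chain here would give a number.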